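The source may hold more compounds than are shown below. What is called first, only, known or untested is meant among the compounds shown, and "the series" means these compounds.

Compound 1 `CN1CCN(C(=O)C2CCN(C(=O)c3cc4ccccc4n3Cc3ccc(Cl)cc3)CC2)CC1` is the starting point. In an ADME assay on BE(2)-C cells (Homo sapiens) for cytotoxicity, read by MTT assay, with a stated time of 20 h (a lower number here means that less compound is tolerated, a higher number that more compound is tolerated), compound 1 gives 75600 nM. Compound 3 `O=C(c1cc2ccccc2n1Cc1ccc(Cl)cc1)N1CCC(C(=O)N2CCCC2)CC1`, which carries pyrrolidin-1-yl in place of 4-methylpiperazin-1-yl on a carbonyl carbon, gives 65600 nM in this assay, and the step of a 1.2-fold lower number from compound 1 to compound 3 (0.06 log units; within the scatter) is within the scatter. Compound 2 `CN1CCC(CNC(=O)C2CCN(C(=O)c3cc4ccccc4n3Cc3ccc(Cl)cc3)CC2)CC1` gives only a limit, > 50000 nM in this assay; this is the limit (the limit of > 50000 nM in this assay, at which 1 of the 3 values shown sits). Among the two plain numbers, compound 1 stands highest, with compound 3 nearest. The steps a step that the limit leaves unreadable from compound 1 to compound 2 and a step that the limit leaves unreadable from compound 2 to compound 3 cannot be sized.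

Compound 4 `O=C(c1cc2ccccc2n1Cc1ccc(Cl)cc1)N1CCC(C(=O)N2CCOCC2)CC1` differs from compound 1 in one place: morpholin-4-yl in place of 4-methylpiperazin-1-yl on a carbonyl carbon. Among the compounds with values here, the one readable comparison, compound 1 to compound 3, shows that swapping the amide ring partner moved the number within the scatter, so no step beyond the scatter is expected here either. The step of a 1.1-fold lower number from compound 1 to compound 4 (0.03 log units; within the scatter) is expected to be small. Compound 4 is therefore estimated to give 70000 nM in this assay, with a range from 30000 nM to 160000 nM.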

Compound 4, half-maximal cytotoxic concentration: > 100000 nM
Compound 4 gave a limit, no number (the forecaster's own chance of this, stated with the estimate: 30%); middle value at least 1.4-fold (0.15 log units) away from the limit.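

Compound 4 gives a limit, not a number: the limit of > 100000 nM in this assay, at which 1 of the 4 values shown sits.

Within the data shown here, this is the first ring on this carbonyl carbon to show that the number in this assay can run past those of the two measured ring partners, with an at least 1.3-fold higher number from compound 1 to compound 4 (0.12 log units; that floor lies within the scatter) and an at least 1.5-fold higher number from compound 3 to compound 4 (0.18 log units; that floor lies within the scatter). Both are only floors, so exchanging 4-methylpiperazin-1-yl or pyrrolidin-1-yl for morpholin-4-yl has not yet given a step shown to lie beyond the scatter, and the step between compound 2 and compound 4 cannot be read.

The compounds shown leave open how far compound 4 lies past its limit, and so whether the true step exceeds the scatter. They also leave open what a piperidin-1-yl ring or an open-chain diethylamino group on the same carbonyl carbon would give.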